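The source may hold more compounds than are shown below. What is called first, only, known or untested is meant among the compounds shown, and "the series" means these compounds.

In a functional assay on NCI-H460 cells (Homo sapiens) for antiproliferative activity, read by sulforhodamine B assay, with a stated time of 72 h (a higher number here means a weaker inhibitor, a lower number a stronger inhibitor), compound 1 (`O=C1CS/C(=N/Nc2nncc3ccccc23)N1c1ccccc1`) gives 30 nM and compound 2 (`CCN1C(=O)CS/C1=N/Nc1nncc2ccccc12`) gives 28 nM on the same read-out, so compound 2 stands level with compound 1. Compound 3 (`O=C1CS/C(=N/Nc2nncc3ccccc23)N1`) carries hydrogen in place of ethyl on an amide-type nitrogen in a ring. Among the measured compounds shown here, the only measured step bearing on this, ethyl in place of phenyl at the same nitrogen, stayed within the scatter (a 1.1-fold lower number from compound 1 to compound 2 (0.03 log units; within the scatter)), yet no measured compound has hydrogen there. No step beyond the scatter is expected in this assay here, and the estimated step (a 1.4-fold higher number from compound 2 to compound 3 (0.15 log units; within the scatter)) leans slightly towards a higher number. Compound 3 is expected at 40 nM (estimated range 14 nM to 120 nM).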

Compound 3, half-maximal inhibitory concentration: 19 nM
Beside the measured number, compound 3's estimate is 2.1-fold (0.32 log units) above it, within the range that was stated.
By their numbers in this assay, from the lowest: compounds 3, 2 and 1 (each within the scatter of the next).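

In this assay, hydrogen in place of ethyl on the amide-type nitrogen gives (a 1.5-fold lower number from compound 2 to compound 3 (0.17 log units; within the scatter)), and hydrogen in place of phenyl gives (a 1.6-fold lower number from compound 1 to compound 3 (0.20 log units; within the scatter)). The nitrogen, two ring bonds from the ring sulfur, therefore needs no carbon substituent to hold activity at this level, and hydrogen, ethyl and phenyl stand level there. Nothing available explains this tolerance. The compounds shown leave open whether a longer chain, a carboxylic acid or an amine-bearing chain on this nitrogen would also stay level.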